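Swapping the Hydroxyphenyl for Pyridin-3-yl in Compound 1

The compounds below may be only part of what the source reports. "The series", "measured", "known", "first", "only" and "open" are said of these compounds alone.

Measured compounds:
compound 1 `CC(O)(C(=O)Nc1ccc(S(=O)(=O)c2ccccc2O)cc1)C(F)(F)F` gives 3090 nM
compound 2 `CC(O)(C(=O)Nc1ccc(C(=O)c2ccccc2)cc1F)C(F)(F)F` gives 11000 nM

Both compounds were tested in a functional assay (Cavia porcellus) with sulfonylurea receptors; K-ATP channels (Homo sapiens) as the target; a higher number here means a weaker inhibitor, a lower number a stronger inhibitor. Among the two numbers, compound 1 stands at the lower one, with 3090 nM, and compound 2, with 11000 nM, lies higher by a gap that is beyond the usual scatter. Within the data shown here, no step between compounds that differ in a single place has been worked out, so nothing more than these two values can be read from the pair.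

Compound 3 `CC(O)(C(=O)Nc1ccc(S(=O)(=O)c2cccnc2)cc1)C(F)(F)F` has not yet been measured in this assay. It differs from compound 1 in one place: pyridin-3-yl in place of 2-hydroxyphenyl on a sulfonyl sulfur. Among the measured compounds shown here, no measured step of this kind exists to guide the expectation. The departing group carries a hydrogen-bond donor that the entering group lacks, and the only stated counts make this the whole of the change. On that basis a step upward from compound 1 to compound 3, of a size somewhat beyond the scatter, is expected, a 1.9-fold higher number from compound 1 to compound 3 (0.29 log units; within the scatter). Compound 3 is therefore estimated to give 6000 nM in this assay, within a range from 1500 nM to 25000 nM.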

Compound 3, half-maximal inhibitory concentration: 3500 nM
Compound 3: middle estimate off by 1.7-fold (0.23 log units), on the high side; the measured number falls inside the stated range.
By their numbers in this assay, from the lowest: compounds 1 and 3 (each within the scatter of the next); then compound 2.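

In this assay, among these compounds, the first step between compounds that differ in a single place gives a 1.1-fold higher number from compound 1 to compound 3 (0.05 log units; within the scatter), with pyridin-3-yl in place of 2-hydroxyphenyl on a sulfonyl sulfur. This shows that, at this position, the read-out tolerates a change from 1 hydrogen-bond donor to 0 and from a ring of carbon only to a ring with 1 hetero atom, with no difference beyond the scatter; the hydroxyl of compound 1 is therefore not required for a value of this size when pyridin-3-yl takes the place of the whole group. Nothing measured here explains why the two compounds lie so close.

Two things changed at once in this step, the hydroxyl left and a ring nitrogen entered, so the compounds shown cannot tell whether each change is silent on its own or whether the two cancel, and an unsubstituted phenyl on the sulfonyl sulfur would separate them. Going by these compounds, it also stays open how far this tolerance extends to other groups at the same place, such as pyridin-2-yl, a 2-aminophenyl or a simple methyl.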